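Compound 3 to compound 4 in the cytotoxicity screen

The compounds below may be only part of what the source reports. "The series", "measured", "known", "first", "only" and "open" are said of these compounds alone.

Three members of the series have so far been run in a functional assay on SEM cells (Homo sapiens) for cytotoxicity, with a stated time of 72 h; a lower number here means that less compound is needed, a higher number that more compound is needed for the effect. Compound 1 `C=C[C@@](C)(/C=C/c1ccc(O)c(/C=C/C(=O)O)c1)CCC=C(C)C` returns a limit rather than a number, > 36600 nM. Compound 2 `COc1ccc(/C=C/[C@@](C)(/C=C/c2ccc(O)c(/C=C/C(=O)OC(C)(C)C)c2)CCC=C(C)C)cc1` likewise returns only a limit, > 36600 nM. Compound 3 `C=C[C@@](C)(/C=C/c1ccc(Nc2ccc(F)c(F)c2)cc1)CCC=C(C)C` is also known only as a limit in this assay, > 36600 nM, so no number stands for it. Among the measured compounds shown here, all values shown rest at the limit of > 36600 nM in this assay, at which 3 of the 3 values shown sit, and no step between measured compounds can be computed from them.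

Compound 4 `C=C[C@@](C)(/C=C/c1ccc(-c2cccc(Br)c2)cc1)CCC=C(C)C` remains to be measured in this assay. It differs from compound 3 in one place: 3-bromophenyl in place of (3,4-difluorophenyl)amino on an aromatic carbon. For the measured compounds named here, with compound 3 known only as a limit and no measured step to lean on, the change is expected to give a step that the limit leaves unreadable from compound 3 to compound 4, meaning nothing beyond the scatter. Compound 4 is therefore estimated at 40000 nM, with a range from 10000 nM to 150000 nM, and most likely reported again as a limit only.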

Compound 4, half-maximal effective concentration: > 36600 nM
Compound 4: no number, only a limit (the forecaster's own chance of this, stated with the estimate: 80%); the middle value lies beyond the limit too.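

Compound 3 and compound 4 are both known only as limits in this assay, so no step can be read between them: the limit of > 36600 nM in this assay, at which 4 of the 4 values shown sit.

The compounds shown leave open whether 3-bromophenyl and (3,4-difluorophenyl)amino differ at all in this assay, and what concentration any compound needs for the effect.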